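Swapping fluoro for trifluoromethyl on the phenyl ring

The source may hold more compounds than are shown below. What is called first, only, known or untested is meant among the compounds shown, and "the series" means these compounds.

Of the compounds shown here, two sharing one core have been tested in a functional assay on PC-12 cells (Rattus norvegicus) for cytotoxicity, read by MTT assay, with stated times of 2 h and 24 h, tested at 5 uM; a higher number here means a stronger effect of the compound at the concentration tested, a lower number a weaker effect. Compound 1 `COc1ccc(-n2nc(-c3ccc(C(F)(F)F)cc3O)nc2-c2ccccc2O)cc1` gives 86.6% in this assay. Compound 2 `Oc1cc(C(F)(F)F)ccc1-c1nc(-c2ccccc2O)n(-c2ccccc2F)n1` gives 86.6% in this assay. Within the data shown here, the single step measured so far, no change at the digits printed from compound 1 to compound 2 (within the scatter), exchanged the group on the aromatic nitrogen of the core, and it left the read-out where it was. Compound 2 therefore stands level with compound 1 at the digits shown, with no other neighbour to compare against.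

The next compound, compound 3 `Oc1cc(C(F)(F)F)ccc1-c1nc(-c2ccccc2O)n(-c2ccccc2C(F)(F)F)n1`, differs from compound 2 in one place: trifluoromethyl in place of fluoro on an aromatic carbon. Seen one bond further out, the 2-fluorophenyl becomes a 2-(trifluoromethyl)phenyl.

Among the measured compounds shown here, only one measured step bears on this change, and only loosely: no change at the digits printed from compound 1 to compound 2 (within the scatter) also altered the ring on the aromatic nitrogen, and that alteration moved nothing beyond the scatter. For the measured compounds named here, with no step that swaps fluoro for trifluoromethyl anywhere in this set, the expectation rests on that single indifferent step. The estimate for compound 3 in this assay is therefore 86%, spanning 74% to 96%, which is expected to mean a number 0.6 percentage points lower from compound 2 to compound 3 (within the scatter).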

Compound 3, a percentage reported as activity, at one concentration (the size of the read-out at that concentration, not a potency): 80%
For compound 3 the middle estimate is 6 percentage points above the measured one, within the range that was stated.
By their numbers in this assay, from the lowest: compounds 3, 1 and 2 (each within the scatter of the next).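

Among these compounds, this is the first step that changes a substituent on the ring at the aromatic nitrogen rather than replacing that whole ring: on an aromatic carbon ortho to a large group, fluoro with 1 heavy atom gives way to trifluoromethyl with 4 heavy atoms, and the result is a number 6.6 percentage points lower from compound 2 to compound 3 (within the scatter) in this assay for a group with more heavy atoms at this position. Exchanging the whole ring gives a number 6.6 percentage points lower from compound 1 to compound 3 (within the scatter) and thus adds a second ring exchange on the aromatic nitrogen, so the 4-methoxyphenyl, 2-fluorophenyl and 2-(trifluoromethyl)phenyl compounds all lie within the scatter of one another, and this small set shows no clear dependence of the read-out on which of these three rings is present. Nothing measured here accounts for this flat picture, so the data describe the outcome without explaining it.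

As far as these compounds go, whether an amine, a carboxylic acid or a longer chain such as an ethoxy group on this ring would stay in the same range remains open. All of these values also come from one concentration, so they describe the size of the effect at that concentration and leave any difference in potency among the compounds unresolved.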